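A few compounds are considered here, and "the series" means these few. Any claim that something is new, unique, unknown or untested is made for them only; others in the source may bear on it.

Compounds measured so far in a functional assay on MDA-MB-435 cells (Homo sapiens) for cytotoxicity, read by MTT assay, with a stated time of 72 h; a lower number here means a stronger inhibitor, a higher number a weaker inhibitor
Compound 1 `Nc1cccc(Nc2c(C(=O)NCc3ccc(F)cc3)nc(Br)c3cccnc23)c1` gives 8000 nM
Compound 2 `CC(C)(C)OC(=O)N1CCN(c2c(C(=O)NCc3ccc(F)cc3)nc(Br)c3cccnc23)CC1` gives 10000 nM
Compound 3 `N[C@H]1CC[C@H](Nc2c(C(=O)NCc3ccc(Oc4ccccc4)cc3)nc(Br)c3cccnc23)CC1` gives 4000 nM

Compound 3, at 4000 nM, lies within the scatter of compound 1 and gives a lower number than compound 2 by more than the scatter. Still unmeasured is compound 4 `COc1ccc(CNC(=O)c2nc(Br)c3cccnc3c2N[C@H]2CC[C@H](N)CC2)cc1`, which carries methyl in place of phenyl on an oxygen on an aromatic ring, a change from phenoxy to methoxy (methyl in place of phenyl on an oxygen on an aromatic ring). Going by the values given here, no measured pair isolates a change at this place, so there is no direct precedent for its size. The expectation rests only on the small spread of the measured values, from compound 3 at 4000 nM to compound 2 at 10000 nM, and those compounds also differ in other groups. The step of a 1.3-fold higher number from compound 3 to compound 4 (0.10 log units; within the scatter) is expected to point slightly towards a higher number in this assay and to stay within the scatter. For compound 4 the estimated value is 5000 nM, with an expected range from 1500 nM to 15000 nM.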

Compound 4, half-maximal inhibitory concentration: 5000 nM
Beside the measured number, compound 4's estimate shows no gap at the digits printed, within the range that was stated.
By their numbers in this assay, from the lowest: compounds 3, 4, 1 and 2 (each within the scatter of the next, the first and the last beyond it).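

Going by these compounds alone, the pair compound 3 and compound 4 is the first in this set to differ in one place only, and it isolates the group on an oxygen on an aromatic ring. In this assay, putting methyl in place of phenyl there gives a 1.3-fold higher number from compound 3 to compound 4 (0.10 log units; within the scatter), so this assay does not separate phenoxy from methoxy in this pair, and the outer aromatic ring is not required for the cytotoxicity seen here. No measurement at hand offers a reason for this result.

Going by these compounds, whether the same holds beside other groups elsewhere on the shared core stays open, since compound 1 and compound 2 differ from this pair in more than one place. Also open, on these data alone, is whether a hydroxy group, an amine or a longer chain on that aromatic ring would move the number beyond the scatter.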